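Removing the Methoxy Group: Compound 3 to Compound 4

The source may report more compounds than this note shows. Statements on the series, on what has been measured and on what is new or still open speak of the compounds shown alone.

Of the compounds shown here, three have so far been measured in a functional assay on LM7 cells (Homo sapiens) for antiproliferative activity, read by MTT assay, with a stated time of 72 h; on this read-out higher numbers stand for weaker inhibition and lower numbers for stronger inhibition. Compound 1 `O=c1c(CSC(=S)N2CCCC2)coc2ccccc12` gives 6000 nM, compound 2 `O=c1c(CSC(=S)N2CCOCC2)coc2ccccc12` gives 12000 nM, and compound 3 `COc1ccc2occ(CSC(=S)N3CCCCC3)c(=O)c2c1` gives 4700 nM, the lowest of the three numbers, close to compound 1 and further from compound 2. Compound 4 `O=c1c(CSC(=S)N2CCCCC2)coc2ccccc12` differs from compound 3 by hydrogen in place of methoxy on an aromatic carbon. Among the compounds with values here, the only measured step, a 2.0-fold higher number from compound 1 to compound 2 (0.30 log units; within the scatter), concerns a different part of the molecule and stays within the scatter, so no measurement addresses the methoxy directly. The expected step is therefore small, estimated at a 1.3-fold higher number from compound 3 to compound 4 (0.11 log units; within the scatter), with no clear direction beyond the scatter. Compound 4 is expected to give about 6000 nM, within a range from 2500 nM to 14000 nM.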

Compound 4, half-maximal inhibitory concentration: 4600 nM
For compound 4 the middle estimate is 1.3-fold (0.12 log units) above the measured one; measured number inside the range.
By their numbers in this assay, from the lowest: compounds 4, 3, 1 and 2 (each within the scatter of the next, the first and the last beyond it).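

In this assay, hydrogen in place of methoxy on this aromatic carbon gives no step beyond the scatter (a 1.0-fold lower number from compound 3 to compound 4 (0.01 log units; within the scatter)), so these two groups cannot be told apart here. The compounds also compare the amine rings on the shared core: piperidin-1-yl in place of pyrrolidin-1-yl stays within the scatter (a 1.3-fold lower number from compound 1 to compound 4 (0.12 log units; within the scatter)), whereas piperidin-1-yl in place of morpholin-4-yl gives a modest step beyond it (a 2.6-fold lower number from compound 2 to compound 4 (0.42 log units; beyond the scatter)). Open, from the compounds shown here alone, is whether a carboxylic acid or an amine on this aromatic carbon would shift the number. Nothing available explains these results.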